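The compounds below may be only part of what the source reports. "The series", "measured", "known", "first", "only" and "open" are said of these compounds alone.

In a physicochemical assay for solubility, read by chemiluminescence and HPLC, in phosphate buffer, measured as kinetic solubility, with a stated time of 24 h, at pH 7.4, tested at 200 uM (on this read-out lower numbers stand for lower solubility and higher numbers for higher solubility), compound 1 `CC(=O)Nc1ccc(Oc2cncc3sc(C(N)=O)cc23)cc1` gives 18000 nM. Compound 2 `NC(=O)c1cc2c(Oc3ccc(Cl)cc3)cnc(F)c2s1` gives < 1000 nM, and this is a limit of the assay, not a number. Compound 2 therefore has no exact position on the scale. Compound 3 `NC(=O)c1cc2c(Oc3ccc(Cl)cc3)cnc(N)c2s1` keeps the rest of compound 2 but carries amino in place of fluoro on an aromatic carbon, next to the ring nitrogen (amino in place of fluoro on an aromatic carbon). Among the measured compounds shown here, the measured compounds offer no comparison that differs in only one place, so this forecast has no direct precedent and remains uncertain. A modest upward step is expected in this assay, not far beyond the usual scatter, and another result reported only as a limit would be quite possible. The expected change is an at least 1.5-fold higher number from compound 2 to compound 3 (0.17 log units; that floor lies within the scatter). Compound 3 is estimated at 1500 nM, with an expected range of 500 nM to 6000 nM.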

Compound 3, solubility: 5500 nM
Beside the measured number, compound 3's estimate is 3.7-fold (0.56 log units) below it; low and high end bracket the measured number.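

In this assay, among the compounds shown here, amino in place of fluoro on an aromatic carbon, next to the ring nitrogen, provides the first comparison that differs in only one place: an at least 5.5-fold higher number from compound 2 to compound 3 (0.74 log units; beyond the scatter). From the compounds shown here alone, compound 2 is held only by a limit, not a number, so the size of this step is a floor and its true size stays unknown: the limit of < 1000 nM in this assay, at which 1 of the 3 values shown sits. One exchange at this position is therefore enough to carry the read-out beyond the usual scatter, something that compound 1, which differs from both others in more than one place, could not show.

A single pair cannot tell whether a methylamino or a methoxy group at the same position would move the number as far as amino does. Going by these compounds, whether this exchange would give a similar step on the core of compound 1 also remains open.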